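Amide to Urea on a Trimethoxy-Free Long-Chain Inhibitor

A few compounds are considered here, and "the series" means these few. Any claim that something is new, unique, unknown or untested is made for them only; others in the source may bear on it.

Compound 1 `CCCCCCCC/C=C\CCCCCCC/C(S)=N/c1c(OC)cc(OC)cc1OC`: 900 nM
Compound 2 `CCCCCCCC/C=C\CCCCCCCCNC(=O)c1c(C)cccc1C`: 9800 nM
Compound 3 `CCCCCCCCCCCCCCCCCC[S+]([O-])c1c(C)cccc1C`: reported only as a limit, > 10000 nM

Of the compounds shown here, three have been measured in an assay on microsomes from intestinal mucosa for inhibition of acyl-CoA:cholesterol acyltransferase (Oryctolagus cuniculus); a lower number here means a stronger inhibitor, a higher number a weaker inhibitor. Compound 1 gives 900 nM, and compound 2 gives 9800 nM, the higher of the two numbers; the gap between them lies beyond the scatter. For compound 3 the assay reports only a limit, > 10000 nM, which is the limit of > 10000 nM in this assay, at which 1 of the 3 values shown sits. Among the compounds with values here, no two measured compounds differ in a single place, so no measured step sets the scale for what follows.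

Compound 4 `CCCCCCCC/C=C\CCCCCCCCNC(=O)Nc1c(C)cccc1Cl` has not yet been measured. It differs from compound 2 in one place, ((2-chloro-6-methylphenyl)amino in place of 2,6-dimethylphenyl on a carbonyl carbon). Within the data shown here, nothing among the measured compounds shows how this change reads out, so the expectation rests on compound 2 alone. The step is expected to be a 3.9-fold lower number from compound 2 to compound 4 (0.59 log units; beyond the scatter), a shift toward stronger inhibition that goes beyond the scatter. Compound 4 is therefore estimated at 2500 nM, within a range from 600 nM to 9000 nM.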

Compound 4, half-maximal inhibitory concentration: 180 nM
Compound 4: middle estimate off by 14-fold (1.14 log units), on the high side; measured number outside the range, below it.
By their numbers in this assay, from the lowest: compound 4; then compound 1; then compound 2. At a limit, above all of these: compound 3.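

In this assay, putting (2-chloro-6-methylphenyl)amino in place of 2,6-dimethylphenyl on a carbonyl carbon gives a 54-fold lower number from compound 2 to compound 4 (1.74 log units; beyond the scatter), the only single-place step among the compounds shown, and a large one. It shows that this position can move the number far beyond the scatter while the rest of the molecule stays the same. Nothing measured here gives a reason for the size of this step.

The change brings in a nitrogen with its hydrogen-bond donor and a chlorine together, so the compounds shown do not tell their contributions apart; a (2,6-dimethylphenyl)amino group on the same carbonyl carbon would separate them. Going by these compounds, whether the step holds with a longer chain or a fully saturated chain also remains open.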